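Lengthening the side chain of compound 2

The source may hold more compounds than are shown below. What is called first, only, known or untested is meant among the compounds shown, and "the series" means these compounds.

Compound 2 `COC(=O)c1cn(C/C=C(\C)CCC=C(C)C)nn1` gives 3.2 in a physicochemical assay for lipophilicity, measured as octanol-water partition (a higher number here means a more lipophilic compound, a lower number a more polar compound), the lowest of the three measured values. Compound 3 `CCCc1cn(C/C=C(\C)CCC=C(C)C)nn1` gives 4.5 and compound 1 `CC(C)=CCC/C(C)=C/Cn1cc(-c2ccccc2)nn1` gives 4.91. The steps of a number 1.30 log units higher from compound 2 to compound 3 (beyond the scatter) and a number 1.71 log units lower from compound 1 to compound 2 (beyond the scatter) both exchange the group on the aromatic carbon, and both are large. Compound 4 `COC(=O)c1cn(C/C=C(\C)CC/C=C(\C)CCC=C(C)C)nn1` keeps the methoxycarbonyl group and differs from compound 2 only in the chain: 3-methylbut-2-en-1-yl in place of hydrogen on a saturated chain carbon bound to a double-bonded chain carbon. Within the data shown here, none of the measured steps touches the chain, so they show only that this assay separates such compounds clearly. Compound 4 is nonetheless expected to come out higher, by an estimated step of a number 1.70 log units higher from compound 2 to compound 4 (beyond the scatter). The estimate for compound 4 is 4.9, with a range from 4.3 to 5.5.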

Compound 4, partition coefficient: 5.25
Compound 4: the middle estimate sits 0.35 log units below what was measured; the measured number falls inside the stated range.
By their numbers in this assay, from the lowest: compound 2; then compound 3; then compound 1; then compound 4.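

The chain position also moves the number in this assay: with methoxycarbonyl held fixed, adding 3-methylbut-2-en-1-yl gives a number 2.05 log units higher from compound 2 to compound 4 (beyond the scatter). Numerically, this exceeds both steps that exchange the group on the aromatic carbon of compound 2. Nothing available accounts for the size of this step. As far as these compounds go, whether 3-methylbut-2-en-1-yl gives a similar step with phenyl or propyl on the aromatic carbon remains open. So does the effect of an amine or a carboxylic acid on a saturated chain carbon bound to a double-bonded chain carbon.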